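A pyridine nitrogen on the acyl ring of compound 1

The compounds below may be only part of what the source reports. "The series", "measured", "known", "first", "only" and "open" are said of these compounds alone.

Compound 1 `COc1ccccc1C(=O)NC(=O)Nc1ccc(-c2ccccc2)c(C(F)(F)F)c1` was tested in an in vitro ADME assay on microsomes from liver (Rattus norvegicus) for metabolic stability, with a stated time of 30 min (on this read-out lower numbers stand for slow clearance and higher numbers for fast clearance), and gives 15 mL.min-1.g-1 there. Compound 3 `COc1ccccc1C(=O)NC(=O)Nc1ccc(-c2nccs2)c(C(F)(F)F)c1` gives 33 mL.min-1.g-1 in this assay, so that compound 1 sits nearest to it with a 2.2-fold higher number from compound 1 to compound 3 (0.34 log units; beyond the scatter). Compound 2 `COc1ccccc1C(=O)NC(=O)Nc1ccc(-c2ccccc2)c(C(C)C)c1` returns only a limit in this assay, namely < 14 mL.min-1.g-1. Its step reads an at least 1.0-fold lower number from compound 1 to compound 2 (0.02 log units; that floor lies within the scatter).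

Compound 4 `COc1ccncc1C(=O)NC(=O)Nc1ccc(-c2ccccc2)c(C(F)(F)F)c1` differs from compound 1 by 4-methoxypyridin-3-yl in place of 2-methoxyphenyl on a carbonyl carbon. Neither measured step touches this carbonyl-bound ring; both alter the other aryl part of the core. The closest comparison is a 2.2-fold higher number from compound 1 to compound 3 (0.34 log units; beyond the scatter), which also exchanged a carbon-only ring for a ring holding a hetero atom, yet it sits elsewhere. Compound 4 is therefore expected to give 18 mL.min-1.g-1 (between 9 mL.min-1.g-1 and 36 mL.min-1.g-1) in this assay, an estimated step of a 1.2-fold higher number from compound 1 to compound 4 (0.08 log units; within the scatter) at most modest.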

Compound 4, intrinsic clearance in microsomes: < 14 mL.min-1.g-1
Compound 4 ended at the assay's limit (the forecaster's own chance of this, stated with the estimate: 30%); at least 1.2-fold (0.10 log units) between middle value and limit.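

Compound 4 is the only compound shown with a change on the carbonyl-bound ring, and in this assay the exchange gives an at least 1.0-fold lower number from compound 1 to compound 4 (0.02 log units; that floor lies within the scatter). At this place, a ring with a hetero atom brings no rise in the number, unlike the exchange elsewhere in the core, a 2.2-fold higher number from compound 1 to compound 3 (0.34 log units; beyond the scatter). The value of compound 4 is a limit, so the real size of its step cannot be told: the limit of < 14 mL.min-1.g-1 in this assay, at which 2 of the 4 values shown sit.

The compounds shown leave open how far compound 4 lies past that limit. They also leave open whether an amine or a carboxylic acid in place of methoxy on this ring would keep the number there.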